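The compounds below may be only part of what the source reports. "The series", "measured", "known", "first", "only" and "open" are said of these compounds alone.

Measured so far in an assay on CHO cells for antagonist activity at transient receptor potential cation channel subfamily V member 1 (Homo sapiens), read by FLIPR; a higher number here means a weaker inhibitor, a lower number a stronger inhibitor:
compound 1 `CC(C(=O)NCc1ccc(C(F)(F)F)nc1-c1ccc(Cl)c(Cl)c1)c1ccc(NS(C)(=O)=O)c(F)c1` — 0.9 nM
compound 2 `CC(C(=O)NCc1ccc(C(F)(F)F)nc1-n1ccnc1)c1ccc(NS(C)(=O)=O)c(F)c1` — 36.1 nM
compound 3 `CC(C(=O)NCc1ccc(C(F)(F)F)nc1-c1ccc2cc[nH]c2c1)c1ccc(NS(C)(=O)=O)c(F)c1` — 20.3 nM

Compound 3 stands second highest of the three numbers in this assay. Its nearest neighbour is compound 2, and the step of a 1.8-fold lower number from compound 2 to compound 3 (0.25 log units; within the scatter) lies within the scatter. The distant one is compound 1, and the step of a 23-fold higher number from compound 1 to compound 3 (1.35 log units; beyond the scatter) is large.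

Compound 4 `Cc1ccc(CCc2nc(C(F)(F)F)ccc2CNC(=O)C(C)c2ccc(NS(C)(=O)=O)c(F)c2)cc1` is not yet measured. It differs from compound 3 in one place: 2-(4-methylphenyl)ethyl in place of 1H-indol-6-yl on an aromatic carbon. The change keeps a six-membered carbon-only aromatic ring at the same position on the shared core but removes the five-membered ring with its hydrogen-bond donor and adds a two-carbon chain.

The measured steps that bear on this position are a 40-fold higher number from compound 1 to compound 2 (1.60 log units; beyond the scatter) and a 23-fold higher number from compound 1 to compound 3 (1.35 log units; beyond the scatter), both large, and a 1.8-fold lower number from compound 2 to compound 3 (0.25 log units; within the scatter), within the scatter. They show that the group at this position can move the number strongly, with the directly attached 3,4-dichlorophenyl of compound 1 giving the lowest number. Going by the values given here, no measured compound carries a chain-linked group here, so the direction for compound 4 is uncertain.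

For compound 4 a step of a 1.4-fold lower number from compound 3 to compound 4 (0.13 log units; within the scatter) is expected, with a wide range. The estimate for compound 4 in this assay is 15 nM, between 3 nM and 80 nM.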

Compound 4, inhibition constant: 0.6 nM
The estimate for compound 4 lay 25-fold (1.40 log units) above the measured number; the whole stated range lies above it.
By their numbers in this assay, from the lowest: compounds 4 and 1 (each within the scatter of the next); then compounds 3 and 2 (each within the scatter of the next).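

In this assay the 2-(4-methylphenyl)ethyl group on this aromatic carbon gives a 34-fold lower number from compound 3 to compound 4 (1.53 log units; beyond the scatter) and a 60-fold lower number from compound 2 to compound 4 (1.78 log units; beyond the scatter) as two large steps, so a benzene ring carried on a chain works at this position, and direct attachment of the ring is not required for a low number. The step of a 1.5-fold lower number from compound 1 to compound 4 (0.18 log units; within the scatter) lies within the scatter, which puts this chain-linked group level with the directly attached 3,4-dichlorophenyl and shows that two quite different groups can reach the same low range here.

Open, as far as these compounds go, is whether the result depends on the 4-methyl group or on the length of the chain, as a plain 2-phenylethyl, a benzyl, a 3-phenylpropyl or an amine within the chain would show. No measurement at hand gives a reason for any of these steps.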